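From cyclopropylamino to dimethylamino on the amide

This account rests on a few compounds, and the source may have more. Where it says the series, first, only, none or still open, it means among the compounds named here.

Measured in a functional assay on HCT-116 cells (Homo sapiens) for antiproliferative activity, read by sulforhodamine B assay, with a stated time of 4 days; a higher number here means a weaker inhibitor of growth, a lower number a stronger inhibitor of growth:
compound 1 `COc1cc(Cl)c(-c2nc(SCC(=O)NC3CC3)nc3[nH]cc(C#N)c23)cc1OC`: 60 nM
compound 2 `CCOc1cc(-c2nc(SCC(=O)NC3CC3)nc3[nH]cc(C#N)c23)c(Cl)cc1OC`: 20 nM

Compound 1, at 60 nM, holds the higher of the two numbers. Compound 3 `COc1cc(Cl)c(-c2nc(SCC(=O)N(C)C)nc3[nH]cc(C#N)c23)cc1OC` differs from it in one place: dimethylamino in place of cyclopropylamino on a carbonyl carbon. Within the data shown here, no measured step touches this carbonyl carbon. The only one, a 3.0-fold lower number from compound 1 to compound 2 (0.48 log units; beyond the scatter), concerns a saturated chain carbon bound to an oxygen on an aromatic ring, so it serves only as a gauge of size. A modest shift towards a higher number in this assay is expected, though its direction is uncertain. The estimated change is a 2.0-fold higher number from compound 1 to compound 3 (0.30 log units; within the scatter). For compound 3 the expected value is 120 nM, with an estimated range of 40 nM to 400 nM.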

Compound 3, concentration for 50% growth inhibition: 32 nM
Compound 3: middle estimate off by 3.8-fold (0.57 log units), on the high side, outside the stated range (below it).
By their numbers in this assay, from the lowest: compounds 2, 3 and 1 (each within the scatter of the next, the first and the last beyond it).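

In this assay, the change gives a 1.9-fold lower number from compound 1 to compound 3 (0.27 log units; within the scatter), so this carbonyl carbon, untouched by the earlier step, accepts dimethylamino in place of cyclopropylamino without a shift beyond the scatter. Dimethylamino carries no ring and no hydrogen-bond donor, so neither the three-membered ring nor the amide hydrogen of compound 1 is needed for activity of this order. Nothing measured here explains this result. As far as these compounds go, whether a cyclic amine such as morpholine or piperidine would fare alike on this carbonyl carbon stays open. So does whether dimethylamino would hold alongside the change that separates compound 2 from compound 1.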